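The compounds below may be only part of what the source reports. "The series", "measured", "known", "first", "only" and "open" are said of these compounds alone.

Measured so far:
Compound 1, `Cc1cn([C@@H]2O[C@H](CO[Si](C)(C)C(C)(C)C)[C@@]3(OS(=O)(=O)C=C3NC(=O)NC(=O)c3ccccc3)[C@H]2O[Si](C)(C)C(C)(C)C)c(=O)n(C)c1=O`, sits at a limit of the assay in an ADME assay on HEL cells (Homo sapiens) for cytotoxicity, with a stated time of 3 days; on this read-out lower numbers stand for higher toxicity in this test and higher numbers for lower toxicity in this test; compound 1 gives >= 80000 nM.
For the measured compounds named here, compound 2, `Cc1cn([C@@H]2O[C@H](CO[Si](C)(C)C(C)(C)C)[C@@]3(OS(=O)(=O)C=C3NC(N)=O)[C@H]2O[Si](C)(C)C(C)(C)C)c(=O)n(C)c1=O`, is the only compound with a number in this assay; compound 2 gives 16000 nM.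

Going by the values given here, compound 2 therefore stands as the sole real number in the set; the other value is the limit of >= 80000 nM in this assay, at which 1 of the 2 values shown sits, and belongs to compound 1. Compound 3, `CCOC(=O)CNC(=O)NC1=CS(=O)(=O)O[C@@]12[C@@H](CO[Si](C)(C)C(C)(C)C)O[C@@H](n1cc(C)c(=O)n(C)c1=O)[C@@H]2O[Si](C)(C)C(C)(C)C`, differs from compound 2 by (ethoxycarbonyl)methyl in place of hydrogen on an amide-type nitrogen. Among the compounds with values here, the only measured step at that nitrogen is an at least 5.0-fold lower number from compound 1 to compound 2 (0.69 log units; beyond the scatter), in which a benzoyl left and the number fell. The present change runs the other way, a group entering on that nitrogen, but the entering (ethoxycarbonyl)methyl is not a benzoyl, so that step carries over only loosely. A modest rise in this assay is expected, a 2.0-fold higher number from compound 2 to compound 3 (0.30 log units; within the scatter), with a fair chance that only a limit is reached. Compound 3 is estimated at 32000 nM, between 10000 nM and 80000 nM.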

Compound 3, minimum cytotoxic concentration: 16000 nM
For compound 3 the middle estimate is 2.0-fold (0.30 log units) above the measured one; measured number inside the range.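

In this assay, (ethoxycarbonyl)methyl on the amide-type nitrogen gives no change at the digits printed from compound 2 to compound 3 (within the scatter), so this larger group reads the same as hydrogen at this position. Replacing benzoyl with (ethoxycarbonyl)methyl gives an at least 5.0-fold lower number from compound 1 to compound 3 (0.69 log units; beyond the scatter), which matches the reading for hydrogen in place of benzoyl, an at least 5.0-fold lower number from compound 1 to compound 2 (0.69 log units; beyond the scatter), and among the three groups on this nitrogen only benzoyl stands apart. Compound 1 remains at a limit, so the full size of both steps from it is unknown: the limit of >= 80000 nM in this assay, at which 1 of the 3 values shown sits.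

The compounds shown do not tell how a carboxylic acid, an amine or a plain alkyl chain on this nitrogen would read in this assay. They also leave open whether the separation belongs to benzoyl alone or extends to other acyl groups, such as acetyl.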